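Swapping pyridin-2-yl for pyridin-3-yl in compound 3

This account rests on a few compounds, and the source may have more. Where it says the series, first, only, none or still open, it means among the compounds named here.

compound 1 `Cc1sc2nc(-c3ccncc3)c(/C=N/NC(=N)N)n2c1C` gives 55000 nM
compound 2 `Cc1cn2c(/C=N/NC(=N)N)c(-c3cccnc3)nc2s1` gives 6920 nM
compound 3 `N=C(N)N/N=C/c1c(-c2ccccn2)nc2sc(Cl)cn12` gives 9330 nM

In a functional assay on prostate cells (Homo sapiens) for antiproliferative activity (on this read-out higher numbers stand for weaker inhibition of growth and lower numbers for stronger inhibition of growth), compound 3 gives 9330 nM and lies within the scatter of compound 2, while compound 1 stands clearly apart with a higher number, which means weaker inhibition of growth.

The next compound to be tested is compound 4 `N=C(N)N/N=C/c1c(-c2cccnc2)nc2sc(Cl)cn12`, which holds the same atoms as compound 3, joined differently. The counted change is pyridin-3-yl in place of pyridin-2-yl on an aromatic carbon and it is the only difference between the two. Put simply, pyridin-3-yl takes the place of pyridin-2-yl on an aromatic carbon.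

For the measured compounds named here, the three measured compounds differ from one another in more than one place, so no measured step shows this swap alone, and the expectation rests on thin evidence. In this assay compound 2, which also carries pyridin-3-yl, gives 6920 nM and lies within the scatter of compound 3. A shift beyond the scatter is therefore not expected. The estimated change is a 1.2-fold lower number from compound 3 to compound 4 (0.09 log units; within the scatter) and it would be small, at most a slight move toward stronger inhibition. For compound 4 the estimate is 7500 nM with 3000 nM to 20000 nM as the expected range.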

Compound 4, concentration for 50% growth inhibition: 15100 nM
The estimate for compound 4 lay 2.0-fold (0.30 log units) below the measured number; low and high end bracket the measured number.
By their numbers in this assay, from the lowest: compounds 2, 3 and 4 (each within the scatter of the next, the first and the last beyond it); then compound 1.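

In this assay, pyridin-3-yl in place of pyridin-2-yl on an aromatic carbon gives a 1.6-fold higher number from compound 3 to compound 4 (0.21 log units; within the scatter), so with the chloro group present these two pyridine groups cannot be told apart at this position. For the compounds shown here, the other one-place comparison concerns a different site: chloro in place of methyl on an aromatic carbon, with pyridin-3-yl held constant, gives a 2.2-fold higher number from compound 2 to compound 4 (0.34 log units; beyond the scatter), a modest move toward weaker inhibition of growth and the only single change here that clears the usual scatter. No independent measurement is available to explain the size of either step.

On these data alone, the pyridin-4-yl group of compound 1 comes with other differences in the core, so its effect at this position remains unresolved, and it is also open whether a plain phenyl ring, with no ring nitrogen, would behave like the two pyridine groups compared here. On the other site, only methyl and chloro can be compared, so a methoxy group or an amine there could still shift growth inhibition in either direction.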